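Amide-to-ester change at the carbonyl of the pyrrole core

A few compounds are considered here, and "the series" means these few. Any claim that something is new, unique, unknown or untested is made for them only; others in the source may bear on it.

Measured in an assay on HL-60 cells for agonist activity at vitamin D3 receptor (Homo sapiens), read by microscopy, with a stated time of 96 h; a lower number here means that less compound is needed, a higher number that more compound is needed for the effect:
- compound 1 `CCn1c(C(=O)N(CCC#N)CCC#N)ccc1C(CC)(CC)c1ccc(OCC(=O)C(C)(C)C)c(C)c1`: 870 nM
- compound 2 `CCn1c(C(=O)N(CCC#N)CCC#N)ccc1C(CC)(CC)c1ccc(OCC(O)C(C)(C)C)c(C)c1`: 97 nM

Within the data shown here, compound 2 stands lowest of the two numbers in this assay; the single step recorded, a 9.0-fold lower number from compound 1 to compound 2 (0.95 log units; beyond the scatter), separates it from compound 1 by a hydroxyl in place of a carbonyl on the side chain.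

Compound 3 `CCn1c(C(=O)OCc2ccc(F)cc2)ccc1C(CC)(CC)c1ccc(OCC(O)C(C)(C)C)c(C)c1` keeps that hydroxyl side chain and alters the other end: a group of 9 heavy atoms (7 carbon, 1 oxygen, 1 fluorine; one six-membered aromatic ring of carbon only) in place of a group of 9 heavy atoms (6 carbon, 3 nitrogen; no ring), on a carbonyl carbon. Among the measured compounds shown here, no measured step touches this carbonyl position; the only step available concerns the side chain and says nothing about the amide-to-ester exchange. The expectation for compound 3 in this assay therefore rests on compound 2 alone, with no directional pull and a wide range: the step of a 1.0-fold higher number from compound 2 to compound 3 (0.01 log units; within the scatter) is expected to fall within the scatter. Compound 3 is estimated at 100 nM, between 20 nM and 500 nM.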

Compound 3, half-maximal effective concentration: > 50000 nM
Compound 3: only a limit was reported; the forecaster's own chance of this, stated with the estimate: 5%; middle value at least 500-fold (2.69 log units) away from the limit.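

The group on the carbonyl carbon matters far more in this assay than the earlier side-chain change suggested: with the hydroxyl side chain held constant, (4-fluorobenzyl)oxy in place of the group bearing the two nitriles gives an at least 510-fold higher number from compound 2 to compound 3 (2.71 log units; beyond the scatter), a larger step than a 9.0-fold lower number from compound 1 to compound 2 (0.95 log units; beyond the scatter). The group that leaves and the group that enters have the same heavy-atom count, so keeping that count does not keep the response at this position. The reading for compound 3 is only a limit, so the full size of the step stays unknown: the limit of > 50000 nM in this assay, at which 1 of the 3 values shown sits.

This single step changes the amide to an ester and replaces the nitrile chains with the fluorinated benzyl group, so the compounds shown cannot separate those two changes. A 4-fluorobenzyl amide or a nitrile-bearing ester at the same carbonyl carbon would tell them apart.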